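The source may report more compounds than this note shows. Statements on the series, on what has been measured and on what is new or still open speak of the compounds shown alone.

Working notes on the series. Compound 1 `COc1ccccc1/C=C1\CCC/C(=C\c2cccc(OC)c2OC)C1=O` carries 2-methoxyphenyl on both sides of the shared core. In an ADME assay on NHDF cells (Homo sapiens) for cytotoxicity, read by MTT assay, with a stated time of 72 h (a lower number here means a stronger inhibitor, a higher number a weaker inhibitor), compound 1 gives 31300 nM, the highest of the two numbers recorded there. Its nearest neighbour is compound 3 `COc1cccc(/C=C2\CCC/C(=C\c3cc(OC)c(OC)c(OC)c3)C2=O)c1OC`, which in this assay gives 7900 nM; that gap is beyond the scatter. Compound 2 `COc1cccc(/C=C2\CCC/C(=C\c3cccc(Cl)c3Cl)C2=O)c1OC` reaches only a limit of the assay in this assay, at > 50000 nM. Among the compounds with values here, the single measured step at the same place is an at least 1.5-fold higher number from compound 1 to compound 2 (0.20 log units; that floor lies within the scatter); its floor lies within the scatter, and because of the limit of > 50000 nM in this assay, at which 1 of the 3 values shown sits, its true size is unknown.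

Within the data shown here, compound 4 `COc1cc(/C=C2\CCC/C(=C\c3cccc(OC)c3OC)C2=O)ccc1O` is the next member. 4-hydroxy-3-methoxyphenyl in place of 2-methoxyphenyl on a double-bonded chain carbon bound to a double-bonded ring carbon The entering group keeps the methoxy theme of compound 1 and adds a hydroxy, so the change is modest in kind; the step to compound 2 offers no size, and the gap from compound 1 to compound 3 shows that a more heavily oxygenated ring can give a lower number, but no step for that pair is established. The expectation for this assay is therefore a small move toward a lower number, a 1.6-fold lower number from compound 1 to compound 4 (0.19 log units; within the scatter), not clearly beyond the scatter. Compound 4 is estimated at 20000 nM, with a range from 6000 nM to 50000 nM.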

Compound 4, half-maximal inhibitory concentration: 14300 nM
For compound 4 the middle estimate is 1.4-fold (0.15 log units) above the measured one; measured number inside the range.
By their numbers in this assay, from the lowest: compounds 3 and 4 (each within the scatter of the next); then compound 1. At a limit, above all of these: compound 2.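

At the place on a double-bonded chain carbon bound to a double-bonded ring carbon, this assay now gives a step of known size beyond the scatter: 4-hydroxy-3-methoxyphenyl in place of 2-methoxyphenyl gives a 2.2-fold lower number from compound 1 to compound 4 (0.34 log units; beyond the scatter). The earlier step at this place had only a floor within the scatter, whereas 4-hydroxy-3-methoxyphenyl in place of 2,3-dichlorophenyl gives an at least 3.4-fold lower number from compound 2 to compound 4 (0.54 log units; beyond the scatter), so even the floor of this step lies beyond the scatter. Its true size remains unknown because compound 2 stands at a limit: the limit of > 50000 nM in this assay, at which 1 of the 4 values shown sits.

The compounds shown do not separate the contribution of the hydroxy from that of the methoxy within 4-hydroxy-3-methoxyphenyl, and a phenyl carrying the hydroxy alone would bear on that question. On these data alone, it also remains open whether the lower number in this assay would persist with an amine or a carboxylic acid in place of the hydroxy.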